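The source may report more compounds than this note shows. Statements on the series, on what has been measured and on what is new or still open speak of the compounds shown alone.

Working notes on the coumarin-triazole series.

Of the compounds shown here, two have numbers so far. Compound 1 `O=c1cc(Cn2cc(CCCCl)nn2)c2ccc(O)cc2o1` carries a chloro-substituted chain on the triazole; in a functional assay on SW-620 cells (Homo sapiens) for inhibition, read by MTT assay, with a stated time of 72 h (a lower number here means a stronger inhibitor, a higher number a weaker inhibitor), compound 1 gives 59800 nM. Compound 2 `CCCCc1ccc(-c2cn(Cc3cc(=O)oc4cc(O)ccc34)nn2)cc1` carries a butyl-substituted aryl ring in that place; in this assay compound 2 gives 49200 nM. Compound 2 has the lowest of the two numbers, but its nearest neighbour, compound 1, lies within the scatter, so the two cannot be ordered.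

Compound 3 `CCCC1CCC(c2ccc(-c3cn(Cc4cc(=O)oc5cc(O)ccc45)nn3)cc2)CC1` differs from compound 2 in one place: 4-propylcyclohexyl in place of butyl on an aromatic carbon. Going by the values given here, no pair of measured compounds shows a step of this kind, so there is no measured guide to its size. With both measured compounds weak in this assay, the expectation is a small step from compound 2 to compound 3, a 1.4-fold lower number from compound 2 to compound 3 (0.15 log units; within the scatter), not clearly beyond the scatter. Compound 3 is therefore estimated at 35000 nM in this assay, with a range from 12000 nM to 100000 nM.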

Compound 3, half-maximal inhibitory concentration: 37500 nM
Compound 3: the middle estimate sits 1.1-fold (0.03 log units) below what was measured; the range from low to high includes it.
By their numbers in this assay, from the lowest: compounds 3, 2 and 1 (each within the scatter of the next).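

The step at this aromatic carbon in this assay reads a 1.3-fold lower number from compound 2 to compound 3 (0.12 log units; within the scatter), so compound 3 cannot be ordered against compound 2. Going by these compounds alone, this is the first measured change at this place, and it shows that 4-propylcyclohexyl, with its six-membered non-aromatic ring of carbon only, can stand in place of butyl without a change that clears the scatter. No measured data on the compounds offer an account of this result.

Going by these compounds, whether any group at this aromatic carbon can move the number beyond the scatter stays open, and an amine or a carboxylic acid in place of butyl would test this. On these data alone, all three compounds share one core, so the effect of a change to that core on the number also stays open.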